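This account rests on a few compounds, and the source may have more. Where it says the series, first, only, none or still open, it means among the compounds named here.

Series notes. Compound 1 `Nc1nc(N)c2c(-c3ccccc3)cn([C@@H]3O[C@H](CO)[C@@H](O)[C@H]3O)c2n1`, compound 2 `Cc1nc(N)c2c(-c3ccoc3)cn([C@@H]3O[C@H](CO)[C@@H](O)[C@H]3O)c2n1` and compound 3 `Nc1nc(N)c2c(-c3cccs3)cn([C@@H]3O[C@H](CO)[C@@H](O)[C@H]3O)c2n1` share one core and have each been measured in a functional assay on CEM-DNR-bulk cells (Homo sapiens), read by MTT assay, with a stated time of 72 h; a higher number here means a weaker inhibitor, a lower number a stronger inhibitor. In this assay compound 1 returns only the limit > 20000 nM, not a number. In this assay compound 2 likewise returns only the limit > 20000 nM. In this assay compound 3 also returns only the limit > 20000 nM, so compound 3 stands at the limit together with the other two values shown, and nothing separates them. Among the measured compounds shown here, the one step between measured compounds, a step that the two limits leave unreadable from compound 1 to compound 3, cannot be sized because of the limit of > 20000 nM in this assay, at which 3 of the 3 values shown sit. Compound 4 `Nc1nc(N)c2c(-c3ccoc3)cn([C@@H]3O[C@H](CO)[C@@H](O)[C@H]3O)c2n1` has not yet been measured in this assay. The change from compound 3 to compound 4 is furan-3-yl in place of thiophen-2-yl on an aromatic carbon. For the measured compounds named here, no measured step bears on it with a readable size; the only neighbouring step, that from compound 1 to compound 3, is unreadable. The expectation is therefore that compound 4 will again sit at or near the limit, the expected step being a step that the limit leaves unreadable from compound 3 to compound 4. Compound 4 is estimated at 25000 nM in this assay, with a range from 12000 nM to 60000 nM, and most likely reported only as a limit.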

Compound 4, half-maximal inhibitory concentration: > 20000 nM
Compound 4 was reported as a limit; the forecaster's own chance of this, stated with the estimate: 85%; the middle value lies beyond the limit too.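

No step to compound 4 from compound 1, compound 2 or compound 3 can be read in this assay, and all four compounds return only a limit: the limit of > 20000 nM in this assay, at which 4 of the 4 values shown sit.

The compounds shown leave open whether any substituent on the shared core gives a readable value in this assay.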